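A few compounds are considered here, and "the series" means these few. Any claim that something is new, unique, unknown or untested is made for them only; others in the source may bear on it.

Of the compounds shown here, three have so far been measured in an assay on membranes from brain for binding affinity to Adrenergic receptor alpha-1 (Rattus norvegicus); on this read-out higher numbers stand for weaker inhibition and lower numbers for stronger inhibition. Within the data shown here, compound 1 `CC(=O)Nc1ccc2[nH]c(Cc3ccc(Oc4ccccc4)cc3)nc2c1` gives 20000 nM, and compound 2 `CN(c1ccc2[nH]c(Cc3ccc(Oc4ccccc4)cc3)nc2c1)S(C)(=O)=O` gives 2000 nM; the step of a 10-fold lower number from compound 1 to compound 2 (1.00 log units; beyond the scatter) is the only single-point change among them. Compound 3 `Oc1ccc2[nH]c(CN3CCC(Cc4cccc(F)c4)CC3)nc2c1` gives 520 nM, the lowest of the three numbers, with compound 2 nearest and compound 1 furthest. Compound 4 `Oc1ccc2[nH]c(CN3CCC(Cc4c(F)cccc4F)CC3)nc2c1` differs from compound 3 by 2,6-difluorophenyl in place of 3-fluorophenyl on a saturated chain carbon bound to a saturated ring carbon. Among the measured compounds shown here, the one measured step concerns a different group on a different core and does not bear on this exchange; nothing measured speaks to a change in the fluorine pattern on this ring. A step of modest size at most is therefore expected, a 1.3-fold higher number from compound 3 to compound 4 (0.10 log units; within the scatter). Compound 4 is estimated at 650 nM, within 220 nM to 2000 nM.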

Compound 4, half-maximal inhibitory concentration: 2600 nM
Compound 4: middle estimate off by 4.0-fold (0.60 log units), on the low side, outside the stated range (above it).
By their numbers in this assay, from the lowest: compound 3; then compounds 2 and 4 (each within the scatter of the next); then compound 1.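

The fluorine pattern on this ring is not a neutral exchange: 2,6-difluorophenyl in place of 3-fluorophenyl gives a 5.0-fold higher number from compound 3 to compound 4 (0.70 log units; beyond the scatter). Among these compounds, this is the first measured step at this place on the saturated chain carbon, and the earlier step, on a different group and core, did not show that this ring affects the read-out. Nothing available accounts for the size of this step.

On these data alone, whether it follows from the second fluorine or from the changed pattern stays open. So does how an unsubstituted phenyl or a methoxyphenyl would read at this place.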